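The compounds below may be only part of what the source reports. "The series", "measured", "known", "first", "only" and "open" are said of these compounds alone.

Working notes on the series. In an assay on membranes from HEK293 cells for displacement of a labelled ligand from adenosine receptor A2b (Homo sapiens), read by scintillation counting, with a stated time of 30 min, tested at 1 uM (on this read-out higher numbers stand for more inhibition at the one concentration tested (going by the name of the read-out) and lower numbers for less inhibition), compound 1 `CC1=C(C(=O)OC(C)(C)C)C(c2ccsc2)NC(=O)N1` gives 47%, the higher of the two numbers measured. Compound 2 `CC1=C(C(=O)OCc2ccccc2)C(c2ccsc2)NC(=O)N1` gives 44%, and the step of a number 3 percentage points lower from compound 1 to compound 2 (within the scatter) shows that benzyl in place of tert-butyl on the ester oxygen hardly matters. Compound 3 `CC(=O)C1=C(C)NC(=O)NC1c1ccsc1` differs from compound 1 by methyl in place of tert-butoxy on a carbonyl carbon. Within the data shown here, no measured step bears directly on this change, since the only comparison swaps one ester alkyl for another while the ester oxygen stays. A small shift is therefore expected, estimated as a number 7 percentage points lower from compound 1 to compound 3 (within the scatter). Compound 3 is expected to give about 40%, between 15% and 65%.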

Compound 3, a percentage reported as inhibition, at one concentration (the size of the read-out at that concentration, not a potency): 24%
Compound 3: the middle estimate sits 16 percentage points above what was measured, within the range that was stated.
By their numbers in this assay, from the lowest: compound 3; then compounds 2 and 1 (each within the scatter of the next).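

With methyl in place of tert-butoxy on a carbonyl carbon, the result is a number 23 percentage points lower from compound 1 to compound 3 (beyond the scatter). This position therefore responds to the change, which the swap of one ester alkyl group for another, a number 3 percentage points lower from compound 1 to compound 2 (within the scatter), did not show. No available data give a reason for the drop. The compounds shown leave open whether the ester oxygen itself or the size of the whole group on the carbonyl carbon accounts for the step. Ethyl, methoxy or a dimethylamino group at this place would bear on that question.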